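Carboxymethyl for methylsulfonyl on the acyl amide nitrogen

A few compounds are considered here, and "the series" means these few. Any claim that something is new, unique, unknown or untested is made for them only; others in the source may bear on it.

Of the compounds shown here, two have been measured so far in an assay on HEK293 cells for agonist activity at Bile acid receptor (Homo sapiens); on this read-out lower numbers stand for an effect already at smaller amounts and higher numbers for an effect only at larger amounts of compound. Compound 1 `CCO[C@]1(c2ccc(OCc3c(-c4c(Cl)cccc4Cl)noc3C3CC3)cc2Cl)C[C@H](c2cccc(C(=O)O)c2)C1` gives 220 nM. Compound 2 `CS(=O)(=O)NC(=O)c1ccc(C2CC2c2ccc(OCc3c(-c4c(Cl)cccc4Cl)noc3C3CC3)cc2Cl)cc1` gives 44 nM, the lower of the two numbers, and its gap to compound 1 lies beyond the usual scatter. Among the measured compounds shown here, compound 1 and compound 2 differ in more than one place, so no single step between them is counted, and the pair shows only that the two values differ.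

Compound 3 `O=C(O)CNC(=O)c1ccc(C2CC2c2ccc(OCc3c(-c4c(Cl)cccc4Cl)noc3C3CC3)cc2Cl)cc1` is the next compound to be measured in this assay. It differs from compound 2 in one place: carboxymethyl in place of methylsulfonyl on an amide-type nitrogen. For the measured compounds named here, no measured pair follows the same change, so the expectation rests on compound 2 alone, which gives 44 nM. The step of a 2.3-fold higher number from compound 2 to compound 3 (0.36 log units; beyond the scatter) is expected to be a modest increase, at the edge of the scatter rather than far beyond it. For compound 3 the estimate is 100 nM, with a range from 40 nM to 300 nM.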

Compound 3, half-maximal effective concentration: 209 nM
Estimate against measurement, compound 3: 2.1-fold (0.32 log units) below, and the stated range covers the measured number.
By their numbers in this assay, from the lowest: compound 2; then compounds 3 and 1 (each within the scatter of the next).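

Carboxymethyl in place of methylsulfonyl on the amide-type nitrogen gives a 4.8-fold higher number from compound 2 to compound 3 (0.68 log units; beyond the scatter) in this assay and is the first single change that can be read in the series, showing that the read-out responds to the group at this place. Both groups count 4 heavy atoms and no ring, so the step appears with no change in those counts, while the entering group brings 1 hydrogen-bond donor and the leaving group has none. Nothing on hand ties the step to a property of either group, and a single pair cannot separate the loss of the sulfonyl unit from the gain of the carboxymethyl chain.

Still open, as far as these compounds go, is how other groups on the same amide-type nitrogen would read, for example phenylsulfonyl, trifluoromethylsulfonyl or a longer chain such as carboxyethyl, and whether any of them would return the number of compound 2 or go lower. Among the compounds shown here, also open is whether this change reads the same way on a different core, as this one pair is the only example of it so far.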